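A Dichlorophenyl Replaces an Aminophenyl on the Carbonyl Carbon

This account rests on a few compounds, and the source may have more. Where it says the series, first, only, none or still open, it means among the compounds named here.

Compound 1 `COc1cc(-c2cc(/C=C/C(=O)c3ccc(N)cc3)[nH]n2)cc(OC)c1OC` was tested in a functional assay on UO-31 cells (Homo sapiens) for cytotoxicity, read by sulforhodamine B assay, with a stated time of 48 h, tested at 0.1 uM (a lower number here means a stronger effect, a higher number a weaker effect of the compound at the concentration tested), and gave 91%. Among the compounds with values here, its companion compound 2 `COc1ccc(-c2cc(/C=C/C(=O)c3ccc(OC)c(OC)c3)[nH]n2)cc1` gave 87% in this assay, a number within the usual scatter of the one for compound 1, so both compounds show only a faint effect at this concentration. Of the two numbers, that of compound 1 is the highest, but the gap to compound 2 lies within the scatter and supports no order between them.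

Compound 3 `COc1cc(-c2cc(/C=C/C(=O)c3ccc(Cl)c(Cl)c3)[nH]n2)cc(OC)c1OC` has not yet been measured. It differs from compound 1 in one place: 3,4-dichlorophenyl in place of 4-aminophenyl on a carbonyl carbon. Within the data shown here, no step between measured compounds that differ in one place is available, so the outcome of this change cannot be read from a precedent and is stated here only as an expectation. Because compound 1 gives 91%, the step from it is expected to be small, a number 3 percentage points lower from compound 1 to compound 3 (within the scatter), with no direction beyond the scatter. Compound 3 is therefore estimated to give 88% in this assay, within a range from 70% to 102%.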

Compound 3, a percentage reported as activity, at one concentration (the size of the read-out at that concentration, not a potency): 85%
For compound 3 the middle estimate is 3 percentage points above the measured one; low and high end bracket the measured number.
By their numbers in this assay, from the lowest: compounds 3, 2 and 1 (each within the scatter of the next).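

In this assay, within the data shown here, 3,4-dichlorophenyl in place of 4-aminophenyl on a carbonyl carbon gives a number 6 percentage points lower from compound 1 to compound 3 (within the scatter), the only step read so far at this place and the first sight of how the shared core responds to a change there. The exchange is a large one in what is counted, since the hydrogen-bond donor and acceptor of 4-aminophenyl leave and two chlorine atoms enter, yet at this single concentration the two compounds cannot be told apart, so this place shows no sensitivity to this particular change. No measurement at hand bears on why the outcome is as it is.

From the compounds shown here alone, it stays open whether a different group on the carbonyl carbon, such as a carboxylic acid, a morpholine ring or a longer chain, would give a step beyond the scatter. Going by these compounds, with all the numbers lying close together at one concentration, it also stays open whether compound 1 and compound 3 would separate at higher concentrations.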